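Replacing the aryl group on the shared core: compound 4

The compounds below may be only part of what the source reports. "The series", "measured", "known", "first", "only" and "open" are said of these compounds alone.

Compound 1, `Nc1ccccc1-c1cnc(C(=O)CCCCCCc2ccccc2)o1`, gives 750 nM in an assay (Rattus norvegicus) for inhibition of Fatty-acid amide hydrolase 1 (Homo sapiens); on this read-out lower numbers stand for stronger inhibition and higher numbers for weaker inhibition.
Compound 2, `O=C(CCCCCCc1ccccc1)c1ncc(-c2ccc([N+](=O)[O-])cc2)o1`, gives 50 nM in this assay.
Compound 3, `Cc1cccnc1-c1cnc(C(=O)CCCCCCc2ccccc2)o1`, gives 15 nM in this assay.

Compound 3 stands at the lowest number of the three in this assay; its nearest neighbour is compound 2, and the gap between them is a 3.3-fold lower number from compound 2 to compound 3 (0.52 log units; beyond the scatter), while the gap to the furthest of the three is a 50-fold lower number from compound 1 to compound 3 (1.70 log units; beyond the scatter). Both gaps lie beyond the scatter, so compound 3 is the strongest inhibitor shown.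

Compound 4, `NS(=O)(=O)c1ccc(-c2cnc(C(=O)CCCCCCc3ccccc3)o2)s1`, keeps the shared core and the seven-carbon chain ending in a phenyl ring but changes the aryl group on the core: 5-sulfamoylthiophen-2-yl in place of 3-methylpyridin-2-yl on an aromatic carbon.

Among the measured compounds shown here, two measured steps bear on this position. Changing 2-aminophenyl to 4-nitrophenyl gave a 15-fold lower number from compound 1 to compound 2 (1.18 log units; beyond the scatter), and changing 2-aminophenyl to 3-methylpyridin-2-yl gave a 50-fold lower number from compound 1 to compound 3 (1.70 log units; beyond the scatter). For the measured compounds named here, both show that this aryl group moves the number strongly, and the only group bearing a hydrogen-bond donor, in compound 1, gave the highest number. The incoming 5-sulfamoylthiophen-2-yl also carries a hydrogen-bond donor, so a step towards a higher number is expected in this assay, estimated at a 6.7-fold higher number from compound 3 to compound 4 (0.82 log units; beyond the scatter). Compound 4 is therefore expected to give about 100 nM, within a range from 20 nM to 600 nM.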

Compound 4, inhibition constant: 3 nM
Compound 4: the middle estimate sits 33-fold (1.52 log units) above what was measured, outside the stated range (below it).
By their numbers in this assay, from the lowest: compound 4; then compound 3; then compound 2; then compound 1.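

In this assay, a hydrogen-bond donor on the aryl group does not by itself go with a high number: the 5-sulfamoylthiophen-2-yl group carries one, yet putting it in place of 3-methylpyridin-2-yl gives a 5.0-fold lower number from compound 3 to compound 4 (0.70 log units; beyond the scatter). The same group also beats the two benzene-based aryl groups, with a 17-fold lower number from compound 2 to compound 4 (1.22 log units; beyond the scatter) and a 250-fold lower number from compound 1 to compound 4 (2.40 log units; beyond the scatter); these steps make compound 4 the strongest inhibitor of the four and show that this position can hold a five-membered aromatic ring with a larger substituted group. Nothing measured here explains why this group gives the lowest number.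

The thiophene ring and the sulfamoyl group enter together, so it remains open which of them accounts for the gain, and an unsubstituted thiophen-2-yl, or a thiophene carrying a carboxylic acid or a methylsulfonyl group instead, would help to separate the two. On these data alone, whether the gain would hold with a shorter chain between the core's carbonyl and the phenyl ring also remains open.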